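The source may report more compounds than this note shows. Statements on the series, on what has been measured and on what is new or still open speak of the compounds shown alone.

In an ADME assay on L02 cells (Homo sapiens) for antiproliferative activity, read by MTT assay, with a stated time of 48 h (on this read-out lower numbers stand for stronger inhibition and higher numbers for weaker inhibition), three compounds with a shared core differ only in the group on an amide-type nitrogen. Compound 1 `CCn1c(C(=O)NCCN)ccc1C(CC)(CC)c1ccc(OCCC(O)(CC)CC)c(C)c1` gives 2940 nM, and compound 3 `CCOC(=O)C(CC(=O)OC)NC(=O)c1ccc(C(CC)(CC)c2ccc(OCCC(O)(CC)CC)c(C)c2)n1CC` gives 4280 nM. These two stand level, with a 1.5-fold higher number from compound 1 to compound 3 (0.16 log units; within the scatter). Compound 2 `CCn1c(C(=O)Nc2cccc(C(F)(F)F)c2)ccc1C(CC)(CC)c1ccc(OCCC(O)(CC)CC)c(C)c1` reads > 50000 nM, which is a limit of the assay and not a number. The large moves both involve its 3-(trifluoromethyl)phenyl group: an at least 17-fold higher number from compound 1 to compound 2 (1.23 log units; beyond the scatter) and an at least 11-fold lower number from compound 2 to compound 3 (1.06 log units; beyond the scatter).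

Compound 4 `CCn1c(C(=O)NC(CO)CCO)ccc1C(CC)(CC)c1ccc(OCCC(O)(CC)CC)c(C)c1` carries 3-hydroxy-1-(hydroxymethyl)propyl instead of the group in compound 3: a group of 6 heavy atoms (4 carbon, 2 oxygen; no ring) in place of a group of 11 heavy atoms (7 carbon, 4 oxygen; no ring), on an amide-type nitrogen. Like the groups in compound 1 and compound 3, it has no ring, so compound 2 is the weaker guide. The step expected in this assay is small and within the scatter: a 1.2-fold higher number from compound 3 to compound 4 (0.07 log units; within the scatter). For compound 4, the estimated value is 5000 nM, with an expected range of 1800 nM to 16000 nM.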

Compound 4, half-maximal inhibitory concentration: 3040 nM
Compound 4: the middle estimate sits 1.6-fold (0.22 log units) above what was measured; low and high end bracket the measured number.
By their numbers in this assay, from the lowest: compounds 1, 4 and 3 (each within the scatter of the next). At a limit, above all of these: compound 2.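

In this assay the entering 3-hydroxy-1-(hydroxymethyl)propyl group stands level with both other ring-free groups (a 1.4-fold lower number from compound 3 to compound 4 (0.15 log units; within the scatter); a 1.0-fold higher number from compound 1 to compound 4 (0.01 log units; within the scatter)). Among compounds 1, 3 and 4, then, these groups differ in heavy atoms and hydrogen-bond donors without a step beyond the scatter. Compound 2 goes against this level reading (an at least 16-fold lower number from compound 2 to compound 4 (1.21 log units; beyond the scatter)), and its value is a limit and not a number: the limit of > 50000 nM in this assay, at which 1 of the 4 values shown sits.

Going by these compounds, whether plain phenyl would read like 3-(trifluoromethyl)phenyl remains open. So does the reading of a carboxylic acid on this amide-type nitrogen.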